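Pyridyl Substituent Variation in a Corticotropin-Releasing Factor Receptor 1 Series

The source may report more compounds than this note shows. Statements on the series, on what has been measured and on what is new or still open speak of the compounds shown alone.

Measured so far:
compound 1, `CCCN(CCC)c1cc(C)nc2c(-c3ncc(Cl)cc3C)c(C)nn12`: 6.7 nM
compound 2, `CCCN(CCC)c1cc(C)nc2c(-c3ncccc3C)c(C)nn12`: 110 nM

In an assay on isolated protein for binding affinity to corticotropin-releasing factor receptor 1 (Homo sapiens) (a higher number here means a weaker inhibitor, a lower number a stronger inhibitor), compound 2 gives 110 nM, the higher of the two numbers in the set. Within the data shown here, the only neighbour is compound 1, which gives 6.7 nM; the step of a 16-fold higher number from compound 1 to compound 2 (1.22 log units; beyond the scatter) shows that removing the chloro from the pyridine ring costs a good deal of affinity.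

Compound 3, `CCCN(CCC)c1cc(C)nc2c(-c3ncc(C)cc3N=O)c(C)nn12`, is not yet measured. It differs from compound 2 by a group of 9 heavy atoms (6 carbon, 2 nitrogen, 1 oxygen; one six-membered aromatic ring with 1 hetero atom) in place of a group of 7 heavy atoms (6 carbon, 1 nitrogen; one six-membered aromatic ring with 1 hetero atom), on an aromatic carbon. The entering group again carries two substituents on the pyridine ring, a methyl and a nitroso, whereas compound 2 carries only a methyl. Among the measured compounds shown here, the step of a 16-fold higher number from compound 1 to compound 2 (1.22 log units; beyond the scatter) is the only measured step that bears on this change, and it says that a second substituent on the pyridine ring can lower the number strongly. Nothing in the set speaks to a nitroso, so the size is uncertain. The expectation for compound 3 in this assay is therefore a step of a 4.4-fold lower number from compound 2 to compound 3 (0.64 log units; beyond the scatter), toward a lower number. Compound 3 is estimated at 25 nM, with a range from 6 nM to 110 nM.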

Compound 3, inhibition constant: > 10000 nM
Compound 3: no number, only a limit; the forecaster's own chance of this, stated with the estimate: 5%; middle value at least 400-fold (2.60 log units) away from the limit.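

In this assay, the step of an at least 90-fold higher number from compound 2 to compound 3 (1.95 log units; beyond the scatter) shows that a second substituent on the pyridine ring does not by itself lower the number, so the gain seen with the chloro of compound 1 does not carry over to every two-substituent pattern. The step of an at least 1400-fold higher number from compound 1 to compound 3 (3.17 log units; beyond the scatter) shows that the pyridine group attached at this aromatic carbon can span the whole range of the set while the rest of the molecule stays the same, and that the choice and arrangement of its substituents matter far more than compound 1 and compound 2 alone suggested. The size of both steps remains open-ended, as compound 3 gives a limit and not a number: the limit of > 10000 nM in this assay, at which 1 of the 3 values shown sits.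

The compounds shown leave open whether the loss belongs to the nitroso itself or to the changed arrangement of methyl and second substituent on the pyridine ring. They also do not tell how an amine, a nitrile or a methoxy group in place of the nitroso would read in this assay, or whether a fluoro or bromo would match the chloro of compound 1.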